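The source may hold more compounds than are shown below. What is called first, only, known or untested is meant among the compounds shown, and "the series" means these compounds.

Compound 1 `BrCCCOc1c(Br)cc(Br)cc1Oc1ccc(Br)cc1Br` gives 30.3 ug/mL in a functional assay on U-937 cells (Homo sapiens) for cytotoxicity, read by MTT assay, with a stated time of 24 h; a higher number here means a weaker inhibitor, a lower number a stronger inhibitor.
Compound 2 `BrCCCCCCOc1c(Br)cc(Br)cc1Oc1ccc(Br)cc1Br` gives 33.8 ug/mL in this assay.

Of these two, compound 2 carries the top number, yet the gap is small: a 1.1-fold higher number from compound 1 to compound 2 (0.05 log units; within the scatter). Compound 3 `COc1c(Br)cc(Br)cc1Oc1ccc(Br)cc1Br` differs from compound 2 in one place: hydrogen in place of 5-bromopentyl on a saturated chain carbon bound to an oxygen on an aromatic ring. Going by the values given here, the only measured step that bears on this change in the chain is a 1.1-fold higher number from compound 1 to compound 2 (0.05 log units; within the scatter), which stayed within the scatter. Cutting the chain back to methyl goes further than that pair did, so the expectation rests on a single small step; no shift beyond the scatter is expected, a 1.0-fold higher number from compound 2 to compound 3 (0.02 log units; within the scatter). Compound 3 is estimated at 35 ug/mL, in a range from 15 ug/mL to 80 ug/mL.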

Compound 3, half-maximal inhibitory concentration: 34.5 ug/mL
The estimate for compound 3 lay 1.0-fold (0.01 log units) above the measured number; the measured number falls inside the stated range.
By their numbers in this assay, from the lowest: compounds 1, 2 and 3 (each within the scatter of the next).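

Cutting the chain back to the methyl ether leaves the number in this assay within the scatter: hydrogen in place of 5-bromopentyl gives a 1.0-fold higher number from compound 2 to compound 3 (0.01 log units; within the scatter) and hydrogen in place of 2-bromoethyl gives a 1.1-fold higher number from compound 1 to compound 3 (0.06 log units; within the scatter). At this oxygen on the aromatic ring, then, the three compounds show that a bromine-bearing chain is not needed to reach this level of cytotoxicity, since methyl does as well. Nothing available explains this flat result. Going by these compounds, whether an amine or a carboxylic acid at the end of the chain, or a chain longer than 6-bromohexyl, would move the number stays open.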